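This account rests on a few compounds, and the source may have more. Where it says the series, first, only, none or still open, it means among the compounds named here.

Measured compounds:
compound 1 `Cc1nc(S(C)(=O)=O)ccc1Oc1ncnc(OC2CCN(C(=O)OC3CCC3)CC2)c1F` gives 13.6 nM in a functional assay on isolated protein for inhibition of Glucose-dependent insulinotropic receptor (Homo sapiens), read by HTRF and cAMP accumulation; on this read-out higher numbers stand for an effect only at larger amounts of compound and lower numbers for an effect already at smaller amounts
compound 2 `Cc1nc(S(C)(=O)=O)ccc1Oc1ncnc(OC2CCN(C(=O)SC(C)(C)C)CC2)c1F` gives 4.83 nM in this assay
compound 3 `Cc1nc(S(C)(=O)=O)ccc1Oc1ncnc(OC2CCN(C(=O)SC3CCC3)CC2)c1F` gives 8.51 nM in this assay

All three share one core and differ only in the group attached to the carbonyl carbon of the ring amide. Compound 3 sits between the other two on these numbers, but neither gap is telling: a 1.6-fold lower number from compound 1 to compound 3 (0.20 log units; within the scatter) and a 1.8-fold higher number from compound 2 to compound 3 (0.25 log units; within the scatter) both fall within the scatter. Within the data shown here, the only step beyond it is a 2.8-fold lower number from compound 1 to compound 2 (0.45 log units; beyond the scatter), a modest one.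

Compound 4 `Cc1nc(S(C)(=O)=O)ccc1Oc1ncnc(OC2CCN(C(=O)C(F)(F)F)CC2)c1F` has not yet been measured in this assay. Its change from compound 3 is trifluoromethyl in place of cyclobutylsulfanyl on a carbonyl carbon. The three measured steps all alter this same carbonyl substituent, and the largest of them was modest, while two were within the scatter; none, however, removes the sulfur or oxygen link altogether, as this change does. The expectation is therefore a small step for compound 4, if any, with a somewhat higher number thought more likely than a lower one: a 1.8-fold higher number from compound 3 to compound 4 (0.25 log units; within the scatter). Compound 4 is estimated at 15 nM, within a range of 5 nM to 50 nM.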

Compound 4, half-maximal effective concentration: 151 nM
Beside the measured number, compound 4's estimate is 10-fold (1.00 log units) below it; the measured number lies above the stated range.
By their numbers in this assay, from the lowest: compounds 2, 3 and 1 (each within the scatter of the next, the first and the last beyond it); then compound 4.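

Until now, every group on the carbonyl carbon was attached through a sulfur or an oxygen, and exchanging those groups moved the number only modestly at most. Trifluoromethyl has neither link, and it shows that this position is far from indifferent to what sits there. In this assay the steps of an 18-fold higher number from compound 3 to compound 4 (1.25 log units; beyond the scatter) and a 31-fold higher number from compound 2 to compound 4 (1.50 log units; beyond the scatter) as well as an 11-fold higher number from compound 1 to compound 4 (1.05 log units; beyond the scatter) are all large and beyond the scatter, so the loss appears from each of the three starting groups.

The compounds shown leave open whether the missing link or the trifluoromethyl itself matters, which a plain methyl or a tert-butylamino group on the same carbonyl carbon could help separate. Nothing measured here explains why the number rises so far.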